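Side-chain change in a series held at the limit

A few compounds are considered here, and "the series" means these few. Any claim that something is new, unique, unknown or untested is made for them only; others in the source may bear on it.

Values in a functional assay on BXPC-3 cells (Homo sapiens) for antiproliferative activity, read by MTT assay, with a stated time of 24 h (a lower number here means a stronger inhibitor, a higher number a weaker inhibitor), each one a limit:
Compound 1 `CCn1c(C(=O)N[C@H](C)C(=O)OC)ccc1C(CC)(CC)c1ccc(OCS(=O)(=O)c2ccccc2)c(C)c1`: > 50000 nM
Compound 2 `CCn1c(C(=O)NCCC(=O)OC)ccc1C(CC)(CC)c1ccc(OCS(=O)(=O)c2ccccc2)c(C)c1`: > 50000 nM
Compound 3 `CCn1c(C(=O)N[C@@H](CC(=O)O)C(=O)O)ccc1C(CC)(CC)c1ccc(OCS(=O)(=O)c2ccccc2)c(C)c1`: > 50000 nM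

Compound 3 gives no number in this assay, only the limit > 50000 nM. The whole set looks the same: the limit of > 50000 nM in this assay, at which 3 of the 3 values shown sit.

The next structure is compound 4 `CCn1c(C(=O)N[C@H](CCC(=O)O)C(=O)O)ccc1C(CC)(CC)c1ccc(OCS(=O)(=O)c2ccccc2)c(C)c1`, which keeps the core of compound 3 and differs only in the side chain: 1,3-dicarboxypropyl in place of 1,2-dicarboxyethyl on an amide-type nitrogen. In short, 1,3-dicarboxypropyl stands in place of 1,2-dicarboxyethyl on an amide-type nitrogen.

For the measured compounds named here, three measured steps bear on this place: a step that the two limits leave unreadable from compound 1 to compound 2, a step that the two limits leave unreadable from compound 1 to compound 3 and a step that the two limits leave unreadable from compound 2 to compound 3. None of them has a readable size, so the series offers no measured gain or loss at this nitrogen. No step beyond the scatter is therefore expected in this assay, and no direction can be assigned. The closest reference is compound 3, whose > 50000 nM is a limit. Compound 4 is most likely expected to return a limit as well. For compound 4 the estimated value is 50000 nM, with an expected range of 20000 nM to 100000 nM. The expected change is a number no higher from compound 3 to compound 4 (the limit leaves the size open).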

Compound 4, half-maximal inhibitory concentration: > 50000 nM
Compound 4: a limit, no number (the forecaster's own chance of this, stated with the estimate: 85%); the middle value sits exactly at the limit.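

In this assay compound 4 gives only a limit, > 50000 nM. No step from compound 1, compound 2 or compound 3 to compound 4 can be read, and the set stays uniform: the limit of > 50000 nM in this assay, at which 4 of the 4 values shown sit.

The compounds shown leave open whether any side chain on this amide-type nitrogen gives a readable number in this assay.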